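The source may hold more compounds than are shown below. What is called first, only, known or untested is meant among the compounds shown, and "the series" means these compounds.

Measured compounds in an ADME assay on KB cells (Homo sapiens) for cytotoxicity, read by MTT assay, with a stated time of 72 h; on this read-out higher numbers stand for weaker inhibition and lower numbers for stronger inhibition:
- compound 1 `COc1ccc(C2=C(c3cc(OC)c(OC)c(OC)c3)C(=O)CC2O[SiH2]C(C)(C)C)cc1OC`; value in this assay > 100 ug/mL, a limit of the assay, not a number.
- compound 2 `COc1ccc(C2=C(c3cc(OC)c(OC)c(OC)c3)C(=O)C(O[SiH2]C(C)(C)C)C2)cc1OC(C)C`; value in this assay 7.5 ug/mL.
- compound 3 `COc1ccc(C2=C(c3cc(OC)c(OC)c(OC)c3)CC(O)C2=O)cc1[N+](=O)[O-]`; value in this assay > 100 ug/mL, again a limit of the assay, not a number.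

For the measured compounds named here, compound 1 stands at the limit of this assay, as does compound 3; only compound 2 returns a number, and no single-point step links any pair of the three, so the series gives no measured step to lean on. The one point that can be stated about where compound 1 stands is the limit of > 100 ug/mL in this assay, at which 2 of the 3 values shown sit.

Compound 4 `COC(=O)c1cc(C2=C(c3cc(OC)c(OC)c(OC)c3)C(=O)CC2O[SiH2]C(C)(C)C)ccc1OC` is the next compound to be measured in this assay. Its change from compound 1 is methoxycarbonyl in place of methoxy on an aromatic carbon.

With compound 1 giving only a limit, the step to compound 4 cannot be sized from data. The expectation is that compound 4 stays weak, with a fair chance of a limit again, so the expected step of an at least 1.2-fold lower number from compound 1 to compound 4 (0.09 log units; that floor lies within the scatter) is small and within the scatter, or a modest gain at most. Compound 4 is expected to give about 80 ug/mL in this assay, in the range 20 ug/mL to 200 ug/mL.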

Compound 4, half-maximal inhibitory concentration: > 100 ug/mL
Compound 4: no number, only a limit (the forecaster's own chance of this, stated with the estimate: 55%); at least 1.2-fold (0.09 log units) between middle value and limit.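

In this assay compound 4 gives > 100 ug/mL, a limit and not a number. Compound 1 gives > 100 ug/mL, also a limit, so no step can be read between compound 1 and compound 4. Still open is whether methoxycarbonyl in place of methoxy changes the read-out at all, with most of the series resting on one value: the limit of > 100 ug/mL in this assay, at which 3 of the 4 values shown sit.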